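The source may report more compounds than this note shows. Statements on the series, on what has been measured and on what is new or still open speak of the compounds shown alone.

Measured compounds: compound 1 `CN(C)C(=O)C[C@H](CSc1ccccc1)Nc1c(C(=O)N/N=C/c2ccccc2F)cnc2ccc(F)cc12`; compound 2 `COc1ccc(/C=N/NC(=O)c2cnc3ccc(F)cc3c2N[C@@H](CSc2ccccc2)CC(=O)N(C)C)cc1`; compound 3 `COc1ccc(/C=N/NC(=O)c2cnc3ccc(F)cc3c2N[C@@H](CSc2ccccc2)CC(=O)N(C)C)cc1O`.

In an ADME assay on Vero cells (Chlorocebus sabaeus) for cytotoxicity, read by MTT assay, with a stated time of 72 h (on this read-out higher numbers stand for weaker inhibition and lower numbers for stronger inhibition), compound 1 reaches only the limit > 62.5 ug/mL. For compound 2 the result in this assay is "not determined" (no result reported). Compound 3 likewise shows only the limit > 62.5 ug/mL in this assay, so it stands at the limit of > 62.5 ug/mL in this assay, at which 2 of the 3 values shown sit, with no single number of its own. Among the compounds with values here, the one measured step, a step that the two limits leave unreadable from compound 1 to compound 3, cannot be read as a size for the same reason. Compound 4 `CCCCCCCC/C=N/NC(=O)c1cnc2ccc(F)cc2c1N[C@@H](CSc1ccccc1)CC(=O)N(C)C` differs from compound 3 by octyl in place of 3-hydroxy-4-methoxyphenyl on a carbon with a double bond to nitrogen. Within the data shown here, no measured step bears on this change, and both neighbours sit at the limit, so no readable shift in this assay is expected. The expected step is a step that the limit leaves unreadable from compound 3 to compound 4. Compound 4 is estimated at 70 ug/mL, between 30 ug/mL and 160 ug/mL, most likely again as a limit.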

Compound 4, half-maximal inhibitory concentration: > 62.5 ug/mL
Compound 4: no number, only a limit; the forecaster's own chance of this, stated with the estimate: 70%; the middle value is on the limit's open side.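

Within the data shown here, compound 1, compound 3 and compound 4 each give only a limit in this assay, so no step between them can be read: the limit of > 62.5 ug/mL in this assay, at which 3 of the 4 values shown sit. The compounds shown leave open whether exchanging 2-fluorophenyl, 3-hydroxy-4-methoxyphenyl and octyl changes the read-out at all.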